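Carbamate-bearing five-membered ring restored on the amide carbonyl

The compounds below may be only part of what the source reports. "The series", "measured", "known", "first", "only" and "open" are said of these compounds alone.

For the measured compounds named here, compound 2 `COc1ccc(COC(=O)[C@H](CSCC2CCCCC2)NC(=O)C2CCCC2)cc1` gives 920 nM in an assay on IMR-32 cells for inhibition of Voltage-dependent N-type calcium channel subunit alpha-1B (Homo sapiens) (on this read-out higher numbers stand for weaker inhibition and lower numbers for stronger inhibition), the higher of the two numbers so far. Compound 1 `COc1ccc(COC(=O)[C@H](CSCC2CCCCC2)NC(=O)[C@@H]2CSCN2C(=O)OC(C)(C)C)cc1` gives 390 nM. Going by the values given here, the one measured step bears directly on this case: a 2.4-fold higher number from compound 1 to compound 2 (0.37 log units; beyond the scatter), where a carbamate-bearing five-membered ring gave way to cyclopentyl and the number rose. Compound 3 `COc1ccc(COC(=O)[C@H](CSCC2CCCCC2)NC(=O)[C@@H]2CCCN2C(=O)OC(C)(C)C)cc1` reverses that kind of change: 1-(tert-butoxycarbonyl)pyrrolidin-2-yl in place of cyclopentyl on a carbonyl carbon. The expected step is a 2.0-fold lower number from compound 2 to compound 3 (0.31 log units; beyond the scatter), roughly the measured one run backwards, because compound 1 with its closely related ring gave 390 nM. Compound 3 is estimated at 450 nM, within a range from 180 nM to 1100 nM.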

Compound 3, half-maximal inhibitory concentration: 880 nM
Beside the measured number, compound 3's estimate is 2.0-fold (0.29 log units) below it; the range from low to high includes it.
By their numbers in this assay, from the lowest: compound 1; then compounds 3 and 2 (each within the scatter of the next).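

The 1-(tert-butoxycarbonyl)pyrrolidin-2-yl group on this carbonyl carbon does not separate from cyclopentyl in this assay (a 1.0-fold lower number from compound 2 to compound 3 (0.02 log units; within the scatter)). A tert-butoxycarbonyl-bearing five-membered ring is thus not sufficient at this position: the 3-(tert-butoxycarbonyl)-1,3-thiazolidin-4-yl group of compound 1 stands apart from the pyrrolidine group (a 2.3-fold higher number from compound 1 to compound 3 (0.35 log units; beyond the scatter)). Nothing available accounts for that difference between the two rings.

Still open, going by these compounds, is whether the thiazolidine ring keeps the number of compound 1 with acetyl in place of tert-butoxycarbonyl. On these data alone, a free ring amine at this position is equally open.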